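Capping the Phenol: Compound 1 to Compound 3

The source may hold more compounds than are shown below. What is called first, only, known or untested is meant among the compounds shown, and "the series" means these compounds.

Compound 1 `COc1cc(/C=N/NC(=O)c2cnccn2)ccc1O` sits lowest of the two compounds measured in a functional assay on the whole organism (strain Swiss) for inhibition, with Mus musculus as the target, with stated times of 40 min and 6 h, at a dose of 100 mg/kg by the oral route (a lower number here means less inhibition, a higher number more inhibition at the dose given (going by the name of the read-out)), where compound 1 gives 34.7%. Its nearest neighbour is compound 2 `O=C(N/N=C/c1ccc(O)cc1)c1cnccn1`, which in this assay gives 43.1%; the step of a number 8.4 percentage points higher from compound 1 to compound 2 (within the scatter) lies within the scatter, so the two values cannot be told apart.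

Compound 3 `COc1ccc(/C=N/NC(=O)c2cnccn2)cc1OC` is not yet measured. It differs from compound 1 by methyl in place of hydrogen on an oxygen on an aromatic ring, that is, the hydroxy becomes a methoxy while the shared core is kept.

Among the measured compounds shown here, no measured step shows this change. For the measured compounds named here, the only step recorded, a number 8.4 percentage points higher from compound 1 to compound 2 (within the scatter), removes a methoxy rather than adds a methyl to an oxygen, and it stayed within the scatter. With nothing pointing in either direction, no step beyond the scatter is expected in this assay for compound 3, and the estimated step is a number 1.3 percentage points higher from compound 1 to compound 3 (within the scatter).

Compound 3 is therefore expected to give about 36%, in a range from 20% to 52%.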

Compound 3, a percentage reported as inhibition, in the whole organism at one dose (the size of the read-out at that dose, not a potency): 51.3%
The estimate for compound 3 lay 15.3 percentage points below the measured number; the range from low to high includes it.
By their numbers in this assay, from the lowest: compounds 1, 2 and 3 (each within the scatter of the next, the first and the last beyond it).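

In this assay, methyl in place of hydrogen on an oxygen on an aromatic ring gives a number 16.6 percentage points higher from compound 1 to compound 3 (beyond the scatter), the only step among these compounds that passes beyond the scatter. It shows that this oxygen need not carry a hydrogen for the read-out to hold at the dose given: with the shared core kept, going from hydroxy to methoxy raises the inhibition by a modest amount rather than losing it. Nothing measured here explains why the methoxy reads higher than the hydroxy.

From the compounds shown here alone, whether a longer chain on the same oxygen, such as ethoxy, or a carboxylic acid carried there would continue this rise or reverse it remains open. Going by these compounds, it is also open whether an amine in place of that oxygen would hold the gain, and whether methyl on the oxygen of compound 2 would give a step of similar size.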